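This account rests on a few compounds, and the source may have more. Where it says the series, first, only, none or still open, it means among the compounds named here.

Measured compounds:
compound 1 `O=S1(=O)N=C(OCc2ccccc2)c2ccccc2N1Cc1ccc(Cl)c(Cl)c1` – > 200000 nM
compound 2 `O=C1c2ccccc2N(Cc2ccc(Cl)c(Cl)c2)S(=O)(=O)N1Cc1ccccc1` – > 200000 nM
compound 3 `O=C1c2ccccc2N(Cc2cccc(Cl)c2)S(=O)(=O)N1Cc1ccccc1` – > 200000 nM

In a functional assay on HEL cells (Homo sapiens) for inhibition (on this read-out higher numbers stand for lower toxicity in this test and lower numbers for higher toxicity in this test), compound 1 gives only a limit of the assay, > 200000 nM, not a number. Compound 2 likewise sits at a limit, > 200000 nM. Compound 3 also shows only a limit, > 200000 nM. All three sit together at the limit, (the limit of > 200000 nM in this assay, at which 3 of the 3 values shown sit). Among the compounds with values here, the single measured step, a step that the two limits leave unreadable from compound 2 to compound 3, is therefore unreadable in size. Compound 4 `O=S1(=O)N=C(OCc2ccccc2)c2ccccc2N1Cc1ccccc1` differs from compound 1 by phenyl in place of 3,4-dichlorophenyl on a saturated chain carbon bound to a sulfonamide nitrogen in a ring. Within the data shown here, no measured step resolves this kind of change, so no shift beyond the scatter in this assay can be read out for it. Compound 4 is expected to stay at the limit as well, an estimate of 200000 nM, between 60000 nM and 200000 nM, meaning an expected step of a number no higher from compound 1 to compound 4 (the limit leaves the size open).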

Compound 4, half-maximal cytotoxic concentration: > 200000 nM
Compound 4 gave a limit, no number; the forecaster's own chance of this, stated with the estimate: 85%; the middle value sits exactly at the limit.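

In this assay compound 4 gives only a limit, > 200000 nM, so no size can be read for its step from compound 1. The compounds shown leave open whether any change among them alters toxicity in this test: the limit of > 200000 nM in this assay, at which 4 of the 4 values shown sit.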